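Adding a methoxymethyl group on the furan side

This account rests on a few compounds, and the source may have more. Where it says the series, first, only, none or still open, it means among the compounds named here.

Three measured compounds share one core and differ at a single aromatic carbon. Compound 1 `O/N=C(/Nc1ccccc1)c1ccc2occc2c1` carries hydrogen there, compound 2 `O/N=C(/Nc1cccc(F)c1)c1ccc2occc2c1` carries fluoro, and compound 3 `O/N=C(/Nc1cccc(-c2ccccc2)c1)c1ccc2occc2c1` carries phenyl. In an assay on isolated protein for inhibition of Indoleamine 2,3-dioxygenase 1 (Homo sapiens), read by spectrophotometry (a higher number here means a weaker inhibitor, a lower number a stronger inhibitor), compound 1 reaches only the limit of the assay, > 30000 nM, which is not a number; this is the limit of > 30000 nM in this assay, at which 1 of the 3 values shown sits. In this assay compound 2 gives 32700 nM and compound 3 gives 11000 nM. Of the two numbers shown, compound 2 stands highest, and its nearest neighbour is reached by a 3.0-fold lower number from compound 2 to compound 3 (0.47 log units; beyond the scatter). The other measured steps are a step that the limit leaves unreadable from compound 1 to compound 2 and an at least 2.7-fold lower number from compound 1 to compound 3 (0.43 log units; beyond the scatter).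

Compound 4 `COCc1cc2cc(/C(=N\O)Nc3cccc(F)c3)ccc2o1` keeps the fluoro of compound 2 and changes a different place: methoxymethyl in place of hydrogen on an aromatic carbon. Within the data shown here, none of the measured steps touches this carbon; all three alter the other ring, so they give no direct guide, only the picture that single small groups on this core moved the number modestly at most. For compound 4 the expected step of a 1.3-fold lower number from compound 2 to compound 4 (0.12 log units; within the scatter) is therefore set small, within the scatter. Compound 4 is estimated at 25000 nM, with a range from 9000 nM to 60000 nM.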

Compound 4, half-maximal inhibitory concentration: 7100 nM
Estimate against measurement, compound 4: 3.5-fold (0.55 log units) above; the whole stated range lies above it.
By their numbers in this assay, from the lowest: compounds 4 and 3 (each within the scatter of the next); then compound 2.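

In this assay, methoxymethyl in place of hydrogen on the aromatic carbon next to the ring oxygen gives a 4.6-fold lower number from compound 2 to compound 4 (0.66 log units; beyond the scatter), so a change at this carbon moves the number beyond the usual scatter. Every earlier step altered the other ring, and this one shows that a second place on the shared core can also shift the number, with a group of 3 heavy atoms and no ring. The compounds shown record only the size of this step, and nothing among the measurements accounts for it.

Going by these compounds, with a single group at this carbon, it stays open whether the chain's oxygen is needed, which a plain ethyl group would test, or whether a longer ether chain, an aminomethyl group or a carboxylic acid would move the number further, or the other way. On these data alone, it also stays open whether the phenyl of compound 3 and the methoxymethyl of compound 4, placed together on one molecule, would each keep their own step or would behave differently in combination.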